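A few compounds are considered here, and "the series" means these few. Any claim that something is new, unique, unknown or untested is made for them only; others in the source may bear on it.

Compound 1 `NC1=NC2(CCOCC2)N(OCCCOc2ccccc2Cl)C(N)=N1`: 2700 nM
Compound 2 `NC1=NC2(CCOCC2)N(OCCCOc2ccc(Cl)cc2Cl)C(N)=N1`: 70 nM

In a functional assay on A549 cells (Homo sapiens) for antiproliferative activity, read by MTT assay, with a stated time of 72 h (a higher number here means a weaker inhibitor, a lower number a stronger inhibitor), compound 2 gives 70 nM, the lower of the two numbers. Compound 3 `NC1=NC2(CCOCC2)N(OCCCOc2ccc(Cl)c(Cl)c2)C(N)=N1` is not yet measured. It differs from compound 2 by 3,4-dichlorophenyl in place of 2,4-dichlorophenyl on an oxygen on a saturated carbon: the same atoms, joined differently. Within the data shown here, one measured step bears on this: a 39-fold lower number from compound 1 to compound 2 (1.59 log units; beyond the scatter), a large step that put chloro in place of hydrogen on an aromatic carbon. Compound 3 loses no chloro, so a step of that size is not expected, only a small one towards a higher number. The expected step is a 1.7-fold higher number from compound 2 to compound 3 (0.23 log units; within the scatter). For compound 3 the estimated value is 120 nM, with an expected range of 25 nM to 600 nM.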

Compound 3, half-maximal inhibitory concentration: 790 nM
The estimate for compound 3 lay 6.6-fold (0.82 log units) below the measured number; measured number above the stated range.
By their numbers in this assay, from the lowest: compound 2; then compound 3; then compound 1.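

In this assay, the place of the chloro groups on the ring counts as well as their number: with the same atoms, going from 2,4-dichlorophenyl to 3,4-dichlorophenyl gives an 11-fold higher number from compound 2 to compound 3 (1.05 log units; beyond the scatter), a large loss. Replacing 2-chlorophenyl with 3,4-dichlorophenyl still gives a 3.4-fold lower number from compound 1 to compound 3 (0.53 log units; beyond the scatter), so only a modest gain remains. Nothing measured here explains the difference between the two dichlorophenyl groups. From the compounds shown here alone, whether fluoro or methoxy could stand in for either chloro remains open, as does the effect of a longer chain before the ring.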